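Trifluoromethyl in place of chloro on the urea-side ring

A few compounds are considered here, and "the series" means these few. Any claim that something is new, unique, unknown or untested is made for them only; others in the source may bear on it.

Compound 1 `COc1cc(-c2nn(-c3cccc(NC(=O)Nc4ccc(Cl)c(Cl)c4)c3)cc2-c2ccncc2)ccc1Cl` gives 7320 nM in a functional assay on SK-MEL-28 cells (Homo sapiens) for inhibition, read by sulforhodamine B assay, with a stated time of 48 h; on this read-out higher numbers stand for weaker inhibition of growth and lower numbers for stronger inhibition of growth. Compound 2 `O=C(Nc1cccc(-n2cc(-c3ccncc3)c(-c3ccc(Cl)c(O)c3)n2)c1)Nc1ccc(Cl)c(Cl)c1`, with hydrogen in place of methyl on an oxygen on an aromatic ring, gives 9850 nM in this assay, a step of a 1.3-fold higher number from compound 1 to compound 2 (0.13 log units; within the scatter), so the two values sit within the scatter of each other. Compound 3 `COc1cc(-c2nn(-c3cccc(NC(=O)c4ccccc4)c3)cc2-c2ccncc2)ccc1Cl` reaches only the limit > 100000 nM in this assay. That step, an at least 13-fold higher number from compound 1 to compound 3 (1.13 log units; beyond the scatter), follows phenyl taking the place of (3,4-dichlorophenyl)amino on the carbonyl carbon, and it sits at the limit of > 100000 nM in this assay, at which 1 of the 3 values shown sits.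

Compound 4 `O=C(Nc1cccc(-n2cc(-c3ccncc3)c(-c3ccc(Cl)c(O)c3)n2)c1)Nc1ccc(Cl)c(C(F)(F)F)c1` keeps everything of compound 2 except one change: trifluoromethyl in place of chloro on an aromatic carbon. Going by the values given here, no measured step touches this exact position. The measured steps only show that a small change elsewhere stays within the scatter, while removing the whole (3,4-dichlorophenyl)amino part costs a great deal. A change of one small group for another at the same place is expected to give at most a modest step. Compound 4 is therefore estimated at 8000 nM, between 3000 nM and 25000 nM, a step of a 1.2-fold lower number from compound 2 to compound 4 (0.09 log units; within the scatter) in this assay.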

Compound 4, concentration for total growth inhibition: 3330 nM
For compound 4 the middle estimate is 2.4-fold (0.38 log units) above the measured one; low and high end bracket the measured number.
By their numbers in this assay, from the lowest: compound 4; then compounds 1 and 2 (each within the scatter of the next). At a limit, above all of these: compound 3.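

Among the compounds shown, this is the first change of one small group for another that moves the number beyond the scatter: in this assay, turning 3,4-dichlorophenyl into 4-chloro-3-(trifluoromethyl)phenyl gives a 3.0-fold lower number from compound 2 to compound 4 (0.47 log units; beyond the scatter), a modest gain in inhibition of growth. The earlier step on the oxygen stayed within the scatter, and the loss of the whole (3,4-dichlorophenyl)amino part showed only that removing that part costs a great deal. This result shows that a single group on that ring can shift the number by itself.

From the compounds shown here alone, it remains open whether a nitrile, an amine or a carboxylic acid at this place would do the same, and whether the gain carries over to the core of compound 1. Nothing in the data shown explains why this change lowers the number.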